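Swapping a Benzyl Ether Substituent: Expected Effect on Cell Inhibition

A few compounds are considered here, and "the series" means these few. Any claim that something is new, unique, unknown or untested is made for them only; others in the source may bear on it.

Of the compounds shown here, two have been measured in a functional assay on MGC-803 cells (Homo sapiens) for inhibition, read by MTT assay, with a stated time of 48 h; on this read-out higher numbers stand for weaker inhibition and lower numbers for stronger inhibition. Compound 1 `Cc1ccc(COc2ccc(C(=O)NC(=S)Nc3ccc(C)c(-c4nc5ccccc5[nH]4)c3)cc2)cc1` gives 4980 nM in this assay. Compound 2 `Cc1ccc(NC(=O)NC(=O)c2ccc(OCc3cccc(C(F)(F)F)c3)cc2)cc1-c1nc2ccccc2[nH]1` gives 13100 nM in this assay, the higher of the two numbers, and its gap to compound 1 lies beyond the usual scatter of repeated measurements. The two compounds differ in more than one place, so no single-change comparison between them is available.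

Compound 3 `Cc1ccc(NC(=O)NC(=O)c2ccc(OCc3ccc(F)cc3)cc2)cc1-c1nc2ccccc2[nH]1` has not yet been measured. It differs from compound 2 in one place: 4-fluorophenyl in place of 3-(trifluoromethyl)phenyl on a saturated chain carbon bound to an oxygen on an aromatic ring. In other words, one substituted benzyl ether is exchanged for another, with the ring substituent changing from trifluoromethyl to fluorine and moving position as written in the group names.

Among the measured compounds shown here, no measured pair shows what such an exchange does in this assay, so there is no basis for predicting a shift in either direction. The step from compound 2 to compound 3 is therefore expected to be a 1.3-fold lower number from compound 2 to compound 3 (0.12 log units; within the scatter), within the scatter. For compound 3 the estimated value in this assay is 10000 nM, with a likely range from 4000 nM to 30000 nM.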

Compound 3, half-maximal inhibitory concentration: 160 nM
The estimate for compound 3 lay 63-fold (1.80 log units) above the measured number, and the stated range ends above it.
By their numbers in this assay, from the lowest: compound 3; then compound 1; then compound 2.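

In this assay, the substituted benzyl ether proves to be a sensitive place in this series: 4-fluorophenyl in place of 3-(trifluoromethyl)phenyl on a saturated chain carbon bound to an oxygen on an aromatic ring gives an 82-fold lower number from compound 2 to compound 3 (1.91 log units; beyond the scatter), with the rest of the molecule unchanged. This single exchange therefore moves the number far beyond the usual scatter, even though the groups that leave and enter both contain one six-membered aromatic ring of carbon only, and neither has a hydrogen-bond donor or acceptor. Nothing available here explains why the step is so large.

The substituent and its ring position change together in this step, so the compounds shown cannot separate the effect of exchanging trifluoromethyl for fluorine from the effect of moving the group. On these data alone, whether 3-fluorophenyl or 4-(trifluoromethyl)phenyl at this place would give a number closer to that of compound 3 or of compound 2 remains open, as does the result for plain phenyl or 4-chlorophenyl.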